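The source may report more compounds than this note shows. Statements on the series, on what has been measured and on what is new or still open speak of the compounds shown alone.

Measured compounds:
compound 1, `CC1(C)[C@H](CNc2ccc(F)cc2C(F)(F)F)[C@H]1c1ccc(S(N)(=O)=O)cc1`: -9%
compound 2, `CC1(C)[C@@H](CNc2ccc(F)cc2C(F)(F)F)[C@@H]1c1ccc(S(N)(=O)=O)cc1`: 79%
compound 3, `Cc1cc(F)c(F)cc1NC[C@@H]1[C@@H](c2ccc(S(N)(=O)=O)cc2)C1(C)C`: 15%

All three were tested in a functional assay on the whole organism with Mus musculus as the target, with stated times of 60 min and 30 min, at a dose of 10 mg/kg by the oral route; a higher number here means more inhibition at the dose given (going by the name of the read-out), a lower number less inhibition. Compound 1 stands lowest of the three: compound 3 sits somewhat higher, and compound 2 sits far higher. Among the measured compounds shown here, the only measured step between two compounds that differ in one place is a number 88 percentage points higher from compound 1 to compound 2 (beyond the scatter). That step rests on (the fact that compounds 1 and 2 differ only in the configuration as drawn), so it says nothing about the groups carried on the aromatic ring.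

Compound 4, `CC1(C)[C@H](CNc2ccc(F)cc2OC(F)F)[C@H]1c1ccc(S(N)(=O)=O)cc1`, keeps the configuration drawn for compound 1 and differs from it by difluoromethoxy in place of trifluoromethyl on an aromatic carbon. For the measured compounds named here, no measured step changes this position, so there is no direct guide to the size of the change. Compound 1 gives -9% in this assay, and compound 4 shares its drawn configuration. Compound 4 is therefore expected to move by a number 14 percentage points higher from compound 1 to compound 4 (beyond the scatter), a step within the scatter. The estimated value for compound 4 is 5%, with a range from -20% to 30%.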

Compound 4, a percentage reported as inhibition, in the whole organism at one dose (the size of the read-out at that dose, not a potency): 41%
Compound 4: the middle estimate sits 36 percentage points below what was measured; the measured number lies above the stated range.
By their numbers in this assay, from the lowest: compound 1; then compound 3; then compound 4; then compound 2.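

In this assay, swapping trifluoromethyl for difluoromethoxy on this aromatic carbon gives a number 50 percentage points higher from compound 1 to compound 4 (beyond the scatter) and so shows that this position can move the read-out by a large amount. The earlier step between the mirror images spoke only of configuration, whereas this one keeps the drawn configuration and changes only the group ortho to a large group. Nothing measured here accounts for the rise.

As far as these compounds go, it remains open whether the same swap would have a similar effect in the drawn configuration of compound 2, where the trifluoromethyl compound already stands high. From the compounds shown here alone, how other groups on this aromatic carbon would read, such as methoxy, a nitrile or an amine, also remains open.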